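The source may report more compounds than this note shows. Statements on the series, on what has been measured and on what is new or still open speak of the compounds shown alone.

Compound 1 `CN(C)c1ccc2cc(-c3ccccc3)c(N)nc2c1`: < 0.1 h (a limit)
Compound 2 `CN(C)c1ccc2cc(-c3ccccc3F)c(N)nc2c1`: < 0.1 h (a limit)
Compound 3 `CN(C)c1ccc2cc(-c3cc(Cl)cc(Cl)c3)c(N)nc2c1`: 0.17 h

All three compounds were tested in an ADME assay on microsomes from liver (Mus musculus) for metabolic stability, read by HPLC, with a stated time of 4 h; a lower number here means that the compound disappears faster, a higher number that the compound lasts longer. The values for compound 1 and compound 2 are limits of the assay and not numbers, and the set is dominated by the limit of < 0.1 h in this assay, at which 2 of the 3 values shown sit. Compound 3, at 0.17 h, is the only one of the three with an actual number, so it is the natural starting point.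

The next structure is compound 4 `Nc1nc2cc(N3CCCC3)ccc2cc1-c1cc(Cl)cc(Cl)c1`, with this change from compound 3: pyrrolidin-1-yl in place of dimethylamino on an aromatic carbon. In words, pyrrolidin-1-yl takes the place of dimethylamino on an aromatic carbon. Among the compounds with values here, the only measured step is a step that the two limits leave unreadable from compound 1 to compound 2, which is a different change, a fluoro in place of hydrogen. It therefore gives no guide to size or direction. Within the data shown here, no measured step alters the dimethylamino group, so the expectation rests on compound 3 at 0.17 h.

The expected change is no more than the scatter, a 1.1-fold lower number from compound 3 to compound 4 (0.05 log units; within the scatter). For compound 4 the estimated half-life is 0.15 h, with an expected range of 0.07 h to 0.35 h.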

Compound 4, half-life: 0.2 h
Compound 4: middle estimate off by 1.3-fold (0.12 log units), on the low side; low and high end bracket the measured number.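

In this assay, within the data shown here, pyrrolidin-1-yl in place of dimethylamino on an aromatic carbon gives a 1.2-fold higher number from compound 3 to compound 4 (0.07 log units; within the scatter), the first step in this set that can be read. The two compounds lie within the scatter of each other, so adding the five-membered non-aromatic ring shows no difference that can be told apart from repeat measurement, at least in this single pair. The earlier step, from compound 1 to compound 2, could not show anything of this kind, because both values are limits: the limit of < 0.1 h in this assay, at which 2 of the 4 values shown sit.

On these data alone, it remains open whether a different group at this position, such as morpholin-4-yl or an amine with a longer chain, would give a clearly different half-life. As far as these compounds go, it is also open whether pyrrolidin-1-yl would give the same result in compounds without the two chloro groups.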